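The compounds below may be only part of what the source reports. "The series", "measured", "known", "first", "only" and "open" are said of these compounds alone.

Measured compounds:
compound 1, `Cc1c(OCCCCOc2ccccc2C(=O)O)ccc(C(=O)CC(C)C)c1O`, 92.4%
compound 2, `Cc1ccc(C(=O)O)cc1OCCCCOc1ccc(C(=O)CC2CCCC2)c(O)c1C`, 67.5%

The account follows the step from compound 2 to compound 3. In an assay on HEK293 cells for positive allosteric modulation of metabotropic glutamate receptor 2 (Rattus norvegicus), read by thallium flux, with a stated time of 2.5 min (on this read-out lower numbers stand for smaller maximal responses and higher numbers for larger maximal responses), compound 1 gives 92.4%. In this assay compound 2 gives 67.5%, the lower of the two numbers, and its distance from compound 1 lies beyond the scatter. Compound 3, `Cc1ccc(C(=O)O)cc1OCCCCOc1ccc(C(=O)CC(C)C)c(O)c1C`, has not been measured. It differs from compound 2 in one place: isopropyl in place of cyclopentyl on a saturated chain carbon bound to a carbonyl carbon. Among the measured compounds shown here, no step between two measured compounds covers exactly this change, since compound 1 also carries its carboxylic acid on a different ring from compound 2. The difference between compound 1 and compound 2 therefore cannot be read as the effect of the isopropyl alone. For the step to compound 3 a moderate rise is expected, a number 10.5 percentage points higher from compound 2 to compound 3 (beyond the scatter), pointing toward the number of compound 1 without reaching it with confidence. Compound 3 is estimated at 78%, within a range from 60% to 96%.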

Compound 3, largest response reached (reported as percent of maximum), in percent of the reference or control that the assay uses: 76.9%
Compound 3: middle estimate off by 1.1 percentage points, on the high side; the range from low to high includes it.
By their numbers in this assay, from the lowest: compounds 2 and 3 (each within the scatter of the next); then compound 1.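

With the rest of the molecule unchanged, isopropyl in place of cyclopentyl on a saturated chain carbon bound to a carbonyl carbon gives, in this assay, a number 9.4 percentage points higher from compound 2 to compound 3 (within the scatter), so this assay does not separate the two groups at this position. Among the compounds shown here, the other single change, 5-carboxy-2-methylphenyl in place of 2-carboxyphenyl on an oxygen on a saturated carbon, gives a number 15.5 percentage points lower from compound 1 to compound 3 (beyond the scatter), which places the one step beyond the scatter at the acid-bearing ring and not at the chain end. Nothing given here explains either step.

On these data alone, whether a longer chain, a cyclohexyl group or an amine at this chain end would also leave the response within the scatter remains open. As far as these compounds go, it is also open whether cyclopentyl in place of isopropyl would give a similar step on the 2-carboxyphenyl series of compound 1.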